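Bromomethyl in place of an ester on the shared core

This account rests on a few compounds, and the source may have more. Where it says the series, first, only, none or still open, it means among the compounds named here.

Measured in a functional assay on MDA-MB-231 cells (Homo sapiens) for cytotoxicity, read by MTT assay, with a stated time of 72 h; on this read-out higher numbers stand for an effect only at larger amounts of compound and lower numbers for an effect already at smaller amounts:
- compound 1 `CCOc1c(-c2occ(C)c2C(=O)O)ccc2c(CC)cccc12`: > 10 ug/mL (a limit)
- compound 2 `CCCOC(=O)c1c(C)coc1-c1ccc2c(CC)cccc2c1OC`: > 10 ug/mL (a limit)
- compound 3 `CCOc1c(-c2occ(C)c2C(=O)OC)ccc2c(CC)cccc12`: 1.2 ug/mL

Compound 2 gives > 10 ug/mL, which is a limit of the assay and not a number. It therefore stands at the limit of > 10 ug/mL in this assay, at which 2 of the 3 values shown sit.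

Compound 4 `CCc1cccc2c(OC)c(-c3occ(C)c3CBr)ccc12` has not yet been measured in this assay. It carries bromomethyl in place of propoxycarbonyl on an aromatic carbon. Among the measured compounds shown here, one measured step bears on this change: an at least 8.3-fold lower number from compound 1 to compound 3 (0.92 log units; beyond the scatter), with methyl in place of hydrogen on an oxygen. That step shows that a change in this part of the molecule can carry a compound off the limit, although compound 4 differs more deeply, since the whole propoxycarbonyl leaves. A step to a lower number, of about the same modest size, is therefore expected, with wide uncertainty. The expected change is an at least 2.5-fold lower number from compound 2 to compound 4 (0.39 log units; beyond the scatter). For compound 4 the estimated value is 4 ug/mL, with an expected range from 0.8 ug/mL to 20 ug/mL.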

Compound 4, concentration for half-maximal effect: 4.6 ug/mL
Compound 4: middle estimate off by 1.2-fold (0.06 log units), on the low side; low and high end bracket the measured number.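

In this assay, compound 2 gives > 10 ug/mL, which is a limit of the assay and not a number. The earlier step touched only the oxygen of the carbonyl group, whereas here the whole propoxycarbonyl on an aromatic carbon gives way to bromomethyl, showing that this position can carry a group without a carbonyl and still give a measured value: an at least 2.1-fold lower number from compound 2 to compound 4 (0.33 log units; beyond the scatter). The size of this step is only a bound, since compound 2 sits at the limit: the limit of > 10 ug/mL in this assay, at which 2 of the 4 values shown sit.

The compounds shown leave open whether the bromine itself accounts for the step, or whether hydroxymethyl or an aminomethyl group on the same aromatic carbon would read alike. Also open, going by these compounds, is how a methyl ester at this place would read alongside the methoxy group of compound 4.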